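This account rests on a few compounds, and the source may have more. Where it says the series, first, only, none or still open, it means among the compounds named here.

Working notes on the series, built on the core of compound 1 `CCOC(=O)C12C(=O)OCC=C1COC2c1ccc(F)cc1`. In a functional assay on A549 cells (Homo sapiens) for cytotoxicity, read by MTT assay (on this read-out lower numbers stand for stronger inhibition and higher numbers for weaker inhibition), compound 1 returns only a limit of the assay, > 1000000 nM. Compound 2 `CCOC(=O)C12C(=O)OCC=C1COC2c1cccc(Cl)c1` gives 28400 nM in this assay. Among the compounds with values here, the only measured step is an at least 35-fold lower number from compound 1 to compound 2 (1.54 log units; beyond the scatter), and it is bounded because compound 1 sits at the limit of > 1000000 nM in this assay, at which 1 of the 2 values shown sits. Compound 3 `CCOC(=O)C12C(=O)OCC=C1COC2c1ccc([N+](=O)[O-])cc1` is not yet measured; it carries the change (nitro in place of fluoro on an aromatic carbon). Within the data shown here, no measured step involves a nitro group, and the step from compound 1 to compound 2 alters both the substituent and its place, so it bears on compound 3 only indirectly, by showing that a change on the aryl group can move the number beyond the scatter. A lower number than the limit of compound 1 is therefore expected for compound 3, but with wide uncertainty, the expected step being an at least 5.0-fold lower number from compound 1 to compound 3 (0.69 log units; beyond the scatter). Compound 3 is estimated at 200000 nM, with a range from 20000 nM to 1000000 nM.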

Compound 3, half-maximal inhibitory concentration: 36800 nM
Compound 3: the middle estimate sits 5.4-fold (0.74 log units) above what was measured, and the stated range covers the measured number.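

In this assay, nitro in place of fluoro on an aromatic carbon para to a large group gives an at least 27-fold lower number from compound 1 to compound 3 (1.43 log units; beyond the scatter). Unlike the step to compound 2, this change leaves the place of the substituent fixed, so it shows that exchanging the group alone at this position can move the number beyond the scatter. The full size of the step cannot be read because compound 1 stands at a limit: the limit of > 1000000 nM in this assay, at which 1 of the 3 values shown sits.

The compounds shown leave open whether other groups at this position, such as an amine, a carboxylic acid or a methoxy group, also move the number away from that of compound 1. They also leave open how chloro would read at the place nitro holds in compound 3, which would separate the effect of the group from that of its place.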